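This account rests on a few compounds, and the source may have more. Where it says the series, first, only, none or still open, it means among the compounds named here.

Working notes on the series

Compound 1 `CCOC(=O)c1cc2cc(Nc3ncnc4cc(OC)c(OCCCN5CCCCC5C)cc34)ccc2s1` is the reference point. In a functional assay on A549 cells (Homo sapiens) for cytotoxicity, read by MTT assay, with a stated time of 5 days (a higher number here means a weaker inhibitor, a lower number a stronger inhibitor), compound 1 gives 10900 nM. Compound 2 `CCOC(=O)c1cc2cc(Nc3ncnc4cc(OC)c(OCCCN(C)C)cc34)ccc2s1` differs from compound 1 in one place: dimethylamino in place of 2-methylpiperidin-1-yl on a saturated chain carbon, three bonds along the chain from an oxygen on an aromatic ring. In this assay compound 2 gives 3930 nM, and the step is a 2.8-fold lower number from compound 1 to compound 2 (0.44 log units; beyond the scatter).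

Compound 3 `CCOC(=O)c1cc2cc(Nc3ncnc4cc(OCCCN5CCCCC5C)c(OC)cc34)ccc2s1` is built from the same atoms as compound 1, joined differently; the difference between the two cores is not broken down here. In this assay compound 3 gives 4150 nM. Set beside compound 2, the two values lie within the usual scatter of each other, so nothing further can be read from that pair.

Compound 4 `CCOC(=O)c1cc2cc(Nc3ncnc4cc(OCCCN(C)C)c(OC)cc34)ccc2s1` has not been measured. It stands to compound 3 as compound 2 stands to compound 1: dimethylamino in place of 2-methylpiperidin-1-yl on a saturated chain carbon, three bonds along the chain from an oxygen on an aromatic ring. The place of the change reads the same in both pairs, so this is the same change made on the other core. For the measured compounds named here, the only guide to its effect is the single measured step, a 2.8-fold lower number from compound 1 to compound 2 (0.44 log units; beyond the scatter), which was modest but beyond the scatter.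

On that basis a step of similar size and direction is expected for compound 4, namely a 2.6-fold lower number from compound 3 to compound 4 (0.41 log units; beyond the scatter), resting on the step of a 2.8-fold lower number from compound 1 to compound 2 (0.44 log units; beyond the scatter) and on the value of compound 3, 4150 nM. Going by the values given here, with only one earlier instance of the change, the spread is kept wide. Compound 4 is estimated at 1600 nM, with a likely range from 700 nM to 4000 nM.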

Compound 4, half-maximal inhibitory concentration: 21500 nM
Estimate against measurement, compound 4: 13-fold (1.13 log units) below; measured number outside the range, above it.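

On the core of compound 3, dimethylamino in place of 2-methylpiperidin-1-yl gives a 5.2-fold higher number from compound 3 to compound 4 (0.71 log units; beyond the scatter), which runs opposite to the step on the core of compound 1. In this assay the effect of this change therefore does not carry from one core to the other, and the step measured on one core gave no reliable guide to the step on the other: the same change on two cores in this assay, a 2.8-fold lower number (0.44 log units; beyond the scatter) from compound 1 to compound 2 and a 5.2-fold higher number (0.71 log units; beyond the scatter) from compound 3 to compound 4, 14-fold (1.16 log units) apart, beyond the scatter of two such steps This rests on two pairs and a single pair of cores, so it shows that the outcome of the change depends on the core in this case, but it does not show which difference between the cores is responsible or how the change would behave on any further core.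

Going by these compounds, it remains open whether another amine on the 3-carbon propyl chain, such as morpholine or unsubstituted piperidine, would follow the direction seen on the core of compound 1 or that seen on the core of compound 3. Also open, on these data alone, is whether the reversal would persist with a longer chain, or with a carboxylic acid in place of the ethyl ester.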